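Phenyl on the ring carbon of the compound 1 core

A few compounds are considered here, and "the series" means these few. Any claim that something is new, unique, unknown or untested is made for them only; others in the source may bear on it.

Measured so far:
compound 1, `N#C/N=C1\N(CCCCCOc2ccc(Cl)cc2)C(=O)CN1c1ccncc1`: 8970 nM
compound 2, `N#C/N=C1\N(CCCCCCCOc2ccc(Cl)cc2)C(=O)CN1c1ccncc1`: 3500 nM

In a functional assay on HA22T cells for cytotoxicity against HA22T cell line (Homo sapiens) (a lower number here means a stronger inhibitor, a higher number a weaker inhibitor), compound 1 gives 8970 nM, the highest of the two numbers recorded. Its nearest neighbour is compound 2 with 3500 nM; the step of a 2.6-fold lower number from compound 1 to compound 2 (0.41 log units; beyond the scatter) is modest and concerns only the chain, 2-(4-chlorophenoxy)ethyl in place of 4-chlorophenoxy on a saturated chain carbon.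

Compound 3, `N#C/N=C1\N(CCCCCOc2ccc(Cl)cc2)C(=O)C(c2ccccc2)N1c1ccncc1`, keeps the chain of compound 1 and changes the core instead: phenyl in place of hydrogen on a saturated ring carbon. Among the compounds with values here, no measured step touches this ring carbon, so the only step available, a 2.6-fold lower number from compound 1 to compound 2 (0.41 log units; beyond the scatter), bears on the change merely as a gauge of how much the series moves at all. With nothing to argue for a direction, no step beyond the scatter is expected in this assay, though the range must stay wide.

For compound 3 the expected value in this assay is 8000 nM, estimated to fall between 2500 nM and 25000 nM. The step this estimate implies, a 1.1-fold lower number from compound 1 to compound 3 (0.05 log units; within the scatter), is expected to stay within the scatter.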

Compound 3, half-maximal inhibitory concentration: 3590 nM
Compound 3: middle estimate off by 2.2-fold (0.35 log units), on the high side; the range from low to high includes it.
By their numbers in this assay, from the lowest: compounds 2 and 3 (each within the scatter of the next); then compound 1.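

Read in this assay, the saturated ring carbon of the core proves to be a place that responds to substitution: phenyl in place of hydrogen gives a 2.5-fold lower number from compound 1 to compound 3 (0.40 log units; beyond the scatter) and so brings no loss, even though it adds 6 heavy atoms to the core of compound 1. The earlier step of a 2.6-fold lower number from compound 1 to compound 2 (0.41 log units; beyond the scatter) lay wholly in the chain, so the series now has two separate places where a single change from compound 1 lowers the number in this assay, one in the chain and one on the core. Within the data shown here, nothing measured so far accounts for the effect of the phenyl on this ring carbon.

Still open, from the compounds shown here alone, is whether the step belongs to the aromatic ring as such, which a methyl, a benzyl or a 4-chlorophenyl on the same ring carbon would help to settle. Also open, going by these compounds, is whether this phenyl and the longer chain of compound 2 add up when they are combined in one molecule, or whether the two changes overlap.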